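A Methyl Step from a Compound at the Limit

The source may hold more compounds than are shown below. What is called first, only, known or untested is meant among the compounds shown, and "the series" means these compounds.

- Compound 1 `CC1CCC(=O)N1CC#CCN(C)C`: > 100 mg/kg
- Compound 2 `CCOC(=O)N(C)C(C)C#CCN1CCCC1`: > 100 mg/kg
- Compound 3 `O=C1OCCN1CC#CCn1ccnc1`: > 100 mg/kg

All three compounds were tested in a functional assay on the whole organism for antagonist activity, with Mus musculus as the target (a higher number here means that more compound is needed for the effect, a lower number that less compound is needed), and each entry above is a limit of the assay, not a number. The series therefore shows a single picture: the limit of > 100 mg/kg in this assay, at which 3 of the 3 values shown sit. Within the data shown here, no compound can be ranked against another, and no measured step links any two of them.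

In this assay compound 3 gives > 100 mg/kg, which is a limit. It therefore offers a floor rather than a firm starting value.

Compound 4 `Cc1cncn1CC#CCN1CCOC1=O` departs from compound 3 in one place (methyl in place of hydrogen on an aromatic carbon). It carries methyl in place of hydrogen on an aromatic carbon, on a five-membered aromatic ring with 2 nitrogen, next to the ring atom that bears a large group.

Among the measured compounds shown here, with no measured step to draw on, no shift beyond the usual scatter is expected from this single change. The expected step is a step that the limit leaves unreadable from compound 3 to compound 4, and this estimate is loose. The assay may well report only a limit again for the new compound.

Compound 4 is expected at 120 mg/kg, with an estimated range from 40 mg/kg to 300 mg/kg.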

Compound 4, dose for half-maximal effect: 80 mg/kg
Compound 4: the middle estimate sits 1.5-fold (0.18 log units) above what was measured, and the stated range covers the measured number.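

In this assay, among these compounds, compound 4 gives 80 mg/kg, the first firm number, so this position on the five-membered aromatic ring with 2 nitrogen can carry a methyl in a compound that gives a value rather than a limit. Methyl in place of hydrogen on this aromatic carbon, next to the ring atom that bears a large group, gives an at least 1.2-fold lower number from compound 3 to compound 4 (0.09 log units; that floor lies within the scatter), and since that floor lies within the scatter, the change cannot yet be called a real gain. Compound 4 therefore gives the series its only readable step and its only number, set against an otherwise uniform picture: the limit of > 100 mg/kg in this assay, at which 3 of the 4 values shown sit.

What the compounds shown leave open is how far compound 3 truly lies from compound 4, and so whether this methyl matters beyond the usual scatter at all. They also leave open whether an ethyl group or a chlorine atom at this same place, or a methyl on another carbon of the ring, would give a number or only a limit again.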